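The source may report more compounds than this note shows. Statements on the series, on what has been measured and on what is new or still open speak of the compounds shown alone.

Measured in a functional assay on A549 cells (Homo sapiens) for cytotoxicity, read by MTT assay, with a stated time of 48 h (on this read-out higher numbers stand for weaker inhibition and lower numbers for stronger inhibition), so far: compound 1 `COc1cc(-c2nnc3n2NC(c2ccco2)C(C(=O)c2ccccc2C)S3)cc(OC)c1OC` at 80000 nM; compound 2 `COc1cc(-c2nnc3n2NC(c2ccco2)C(C(=O)c2ccccc2F)S3)cc(OC)c1OC` at 78700 nM; compound 3 `COc1cc(-c2nnc3n2NC(c2ccco2)C(C(=O)c2cccs2)S3)cc(OC)c1OC` at 78700 nM.

On these numbers compound 1 gives the highest of the three, yet its steps to compound 2 and compound 3 both fall within the scatter: a 1.0-fold lower number from compound 1 to compound 2 (0.01 log units; within the scatter) and a 1.0-fold lower number from compound 1 to compound 3 (0.01 log units; within the scatter). Compound 4 `COc1cc(-c2nnc3n2NC(c2ccco2)C(C(=O)c2cccc4ccccc24)S3)cc(OC)c1OC` differs from compound 1 only at the carbonyl carbon, where (naphthalen-1-yl in place of 2-methylphenyl on a carbonyl carbon). Going by the values given here, the steps that bear on this change are those that also vary the group on that carbonyl carbon, a 1.0-fold lower number from compound 1 to compound 3 (0.01 log units; within the scatter) and no change at the digits printed from compound 2 to compound 3 (within the scatter), and neither moved beyond the scatter. The account therefore expects no step beyond the scatter in this assay for compound 4, no change at the digits printed from compound 1 to compound 4 (within the scatter), and estimates compound 4 at 80000 nM, within 40000 nM to 160000 nM.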

Compound 4, half-maximal inhibitory concentration: > 100000 nM
Compound 4 was reported as a limit; the forecaster's own chance of this, stated with the estimate: 15%; at least 1.2-fold (0.09 log units) between middle value and limit.
By their numbers in this assay, from the lowest: compounds 2, 3 and 1 (each within the scatter of the next). At a limit, above all of these: compound 4.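

In this assay, compound 4 is reported only as a limit, not a number: the limit of > 100000 nM in this assay, at which 1 of the 4 values shown sits.

Naphthalen-1-yl on the carbonyl carbon gives an at least 1.2-fold higher number from compound 1 to compound 4 (0.09 log units; that floor lies within the scatter), an at least 1.2-fold higher number from compound 3 to compound 4 (0.10 log units; that floor lies within the scatter) and an at least 1.2-fold higher number from compound 2 to compound 4 (0.10 log units; that floor lies within the scatter). Going by these compounds alone, this is the first change at this position without a measured endpoint, so its true size cannot be read, and it may or may not lie beyond the scatter.

The compounds shown leave open whether any group on this carbonyl carbon moves the number beyond the scatter, for instance an aminophenyl group or a short alkyl chain.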